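The source may hold more compounds than are shown below. What is called first, only, known or untested is meant among the compounds shown, and "the series" means these compounds.

Compound 1 `CN(C)c1nc(N)nc2c1ncn2/C=C1/CC1(CO)CO` gives "not determined" (no result reported) in an ADME assay on MOLT-3 cells (Homo sapiens) for cytotoxicity, with a stated time of 7 days; on this read-out lower numbers stand for higher toxicity in this test and higher numbers for lower toxicity in this test
Compound 2 `CCCCCOc1nc(N)nc2c1ncn2/C=C1/CC1(CO)CO` gives > 20000 nM in this assay

Compound 2 offers no single number in this assay, only a limit: the limit of > 20000 nM in this assay, at which 1 of the 2 values shown sits. For the measured compounds named here, compound 1 has no reported result, so the series holds no step between measured compounds and no measured size of change to draw on.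

The next compound is compound 3 `CCCOc1nc(N)nc2c1ncn2/C=C1/CC1(CO)CO`. Hydrogen replaces ethyl on a saturated chain carbon, three bonds along the chain from an oxygen on an aromatic ring, which turns pentyl into propyl: hydrogen in place of ethyl on a saturated chain carbon, three bonds along the chain from an oxygen on an aromatic ring.

With only the limit of compound 2 as an anchor, no change beyond the scatter is expected in this assay, and neither direction is favoured. The expected change is a number no higher from compound 2 to compound 3 (the limit leaves the size open) in this estimate. Compound 3 is estimated at 20000 nM, with an expected range of 9000 nM to 45000 nM, and a report as a limit is also likely.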

Compound 3, half-maximal cytotoxic concentration: > 20000 nM
Compound 3 was reported as a limit; the forecaster's own chance of this, stated with the estimate: 70%; the middle value lies on the limit itself.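

In this assay no step can be read between compound 2 and compound 3, as both are reported only as limits: the limit of > 20000 nM in this assay, at which 2 of the 3 values shown sit.

The compounds shown leave open where the true cytotoxic concentrations of compound 2 and compound 3 lie, and whether pentyl and propyl differ at all.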